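This account rests on a few compounds, and the source may have more. Where it says the series, first, only, none or still open, it means among the compounds named here.

Compound 1 `CCOc1ccc(C(=O)/C=C/c2ccc(CC)cc2)cc1` and compound 2 `O=C(/C=C/c1cccc(F)c1)c1ccc(-n2ccnc2)cc1` share a core and were both tested in an assay on isolated protein for inhibition of Amine oxidase [flavin-containing] B (Homo sapiens); on this read-out higher numbers stand for weaker inhibition and lower numbers for stronger inhibition. In this assay compound 1 gives 210 nM. For compound 2 the assay returned only a limit, > 10000 nM, so no number is known for it. That limit is the point at which one of the two values shown sits (the limit of > 10000 nM in this assay, at which 1 of the 2 values shown sits), and compound 2 therefore stands at the weak end of what has been measured, while compound 1 stands far from it.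

Compound 3 `O=C(/C=C/c1ccccc1F)c1ccc(-n2ccnc2)cc1` has not yet been measured in this assay. It differs from compound 2 in a single place (2-fluorophenyl in place of 3-fluorophenyl on a double-bonded chain carbon bound to a double-bonded chain carbon). For the measured compounds named here, no measured step of this kind is available, so the expectation rests on the size of the change alone: the same atoms are joined differently, and only the fluorine changes its place on the ring. For so small a rearrangement a step no larger than the usual scatter is expected, in no particular direction, which would leave compound 3 at the limit as well. The expected step is a step that the limit leaves unreadable from compound 2 to compound 3. Compound 3 is estimated at 12000 nM, within a range from 3000 nM to 40000 nM.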

Compound 3, half-maximal inhibitory concentration: > 10000 nM
Compound 3 gave a limit, no number; the forecaster's own chance of this, stated with the estimate: 70%; the middle value does not contradict the limit.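

In this assay compound 2 and compound 3 each returned only a limit, not a number, so no step between them can be read: the limit of > 10000 nM in this assay, at which 2 of the 3 values shown sit.

Still open, from the compounds shown here alone, is whether 2-fluorophenyl in place of 3-fluorophenyl changes inhibition at all, and how weak compound 2 and compound 3 really are.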